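The source may report more compounds than this note shows. Statements on the series, on what has been measured and on what is new or still open speak of the compounds shown alone.

Of the compounds shown here, three of one family have been measured so far. Compound 1 `COc1ccc(-c2cc(/C=C/C(=O)c3ccc(N)cc3)[nH]n2)cc1` is tested in a functional assay on NCI-H23 cells (Homo sapiens) for inhibition, read by sulforhodamine B assay, with a stated time of 48 h (a higher number here means a weaker inhibitor of growth, a lower number a stronger inhibitor of growth), and there compound 1 gives 3220 nM. Compound 2 `COc1ccc(-c2cc(/C=C/C(=O)c3ccc(N)cc3)[nH]n2)cc1OC` carries one more methoxy group on its aromatic ring, and in this assay compound 2 gives 4210 nM. Compound 3 `COc1cc(C(=O)/C=C/c2cc(-c3cc(OC)c(OC)c(OC)c3)n[nH]2)cc(OC)c1OC` has a different core, bearing methoxy groups on both outer rings, and in this assay compound 3 gives 3040 nM. All three numbers sit close together, so none of them can be told apart from the others with confidence.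

The move from compound 2 to compound 1 is a single change, (hydrogen in place of methoxy on an aromatic carbon), and it produced a 1.3-fold lower number from compound 2 to compound 1 (0.12 log units; within the scatter). How the core of compound 3 differs from that of compound 2 is not broken down here.

Compound 4 `COc1ccc(-c2cc(/C=C/C(=O)c3cc(OC)c(OC)c(OC)c3)[nH]n2)cc1OC` has not yet been measured. It arises from compound 3 by hydrogen in place of methoxy on an aromatic carbon. For the measured compounds named here, this is the same kind of change as the one from compound 2 to compound 1, though not the same: in compound 3 the place is in addition meta to a methoxy group (2 heavy atoms). Because the earlier change gave a 1.3-fold lower number from compound 2 to compound 1 (0.12 log units; within the scatter), a step of similar small size is expected here, with compound 4 estimated to show a 1.1-fold higher number from compound 3 to compound 4 (0.04 log units; within the scatter) relative to compound 3. In this assay compound 4 is therefore expected to give about 3300 nM, most likely between 1500 nM and 7500 nM.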

Compound 4, concentration for 50% growth inhibition: 1970 nM
Compound 4: the middle estimate sits 1.7-fold (0.22 log units) above what was measured; low and high end bracket the measured number.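

In this assay, replacing a methoxy group on an aromatic carbon with hydrogen gave a 1.5-fold lower number from compound 3 to compound 4 (0.19 log units; within the scatter). Set beside the earlier case of this change, the two cores agree as far as these measurements can tell: the same change on two cores in this assay, a 1.3-fold lower number (0.12 log units; within the scatter) from compound 2 to compound 1 and a 1.5-fold lower number (0.19 log units; within the scatter) from compound 3 to compound 4, 1.2-fold (0.07 log units) apart, within the scatter of two such steps. So the change carries from one core to the other with no detectable difference in the size of its step, but each step on its own lies within the scatter, so this does not show that taking away the methoxy group affects growth inhibition at all, nor that the two steps are truly identical, and two cores cannot speak for the whole series.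

The compounds shown leave open whether a different group on this aromatic carbon, such as a hydroxyl group, a chlorine atom or a carboxylic acid, would give a step that stands clear of the scatter. They also leave open whether the same swap of methoxy for hydrogen would keep a step of this small size on further cores, or at the other places on these rings that carry a methoxy group.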